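This account rests on a few compounds, and the source may have more. Where it says the series, first, only, none or still open, it means among the compounds named here.

Measured so far:
- compound 1 `COc1ccc(-c2cc(/C=C/C(=O)c3ccc(N)cc3)[nH]n2)cc1`: 99%
- compound 2 `COc1ccc(C(=O)/C=C/c2cc(-c3cc(OC)c(OC)c(OC)c3)n[nH]2)cc1OC`: 101%
- compound 3 `COc1ccc(-c2cc(/C=C/C(=O)c3ccc(N)cc3)[nH]n2)cc1OC`: 91%

All three were tested in a functional assay on OVCAR-5 cells (Homo sapiens) for cytotoxicity, read by sulforhodamine B assay, with a stated time of 48 h, tested at 0.01 uM; a lower number here means a stronger effect, a higher number a weaker effect of the compound at the concentration tested. Compound 1 gives 99%, compound 2 gives 101%, and compound 3 gives 91%; the three numbers lie within the scatter of one another, so none of the three can be called more or less active than the others.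

One pair differs in a single place. Compound 3 arises from compound 1 by methoxy in place of hydrogen on an aromatic carbon, and the step is a number 8 percentage points lower from compound 1 to compound 3 (within the scatter). How the core of compound 2 differs from the core of compound 1 is not broken down here.

Compound 4 `COc1cc(C(=O)/C=C/c2cc(-c3cc(OC)c(OC)c(OC)c3)n[nH]2)cc(OC)c1OC` has not yet been measured. It arises from compound 2 by methoxy in place of hydrogen on an aromatic carbon. Among the compounds with values here, this is the same kind of change as the one from compound 1 to compound 3, though not the same: the entering group in compound 4 also stands meta to a methoxy group, which is not so in compound 3.

The expected step is a number 4 percentage points lower from compound 2 to compound 4 (within the scatter), resting on the step of a number 8 percentage points lower from compound 1 to compound 3 (within the scatter) for the same kind of change and on the fact that compound 2 gives 101%, already near the top of what this read-out reports. Compound 4 is therefore estimated at 97%, expected to fall between 86% and 108%.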

Compound 4, a percentage reported as activity, at one concentration (the size of the read-out at that concentration, not a potency): 97%
Beside the measured number, compound 4's estimate shows no gap at the digits printed, within the range that was stated.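

In this assay, putting methoxy in place of hydrogen on an aromatic carbon gives a number 4 percentage points lower from compound 2 to compound 4 (within the scatter). Set beside the earlier case, the change reads the same on both cores, as far as these numbers can tell: the same change on two cores in this assay, a number 8 percentage points lower (within the scatter) from compound 1 to compound 3 and a number 4 percentage points lower (within the scatter) from compound 2 to compound 4, 4 percentage points apart, within the scatter of two such steps. Within the data shown here, this shows only that neither core gives a step that can be told apart from no change at all, so the agreement between the two steps is an agreement between two null results; it does not show that methoxy has a real effect of a shared size that carries from one core to the other, and a change that truly mattered on a core with a clear effect at this concentration could not be seen here.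

The compounds shown leave open whether a hydroxy group, an ethoxy group or a chlorine atom in place of that same hydrogen would read any differently from methoxy in this assay. They also leave open how the methoxy change would behave on a core whose value stands clearly apart from those of the four compounds here, which is the kind of case that could put the idea of carrying it across cores to a real test.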